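Inverting the stereocentre: from compound 3 to compound 4

This account rests on a few compounds, and the source may have more. Where it says the series, first, only, none or still open, it means among the compounds named here.

In a functional assay on the whole organism with Mus musculus as the target (on this read-out higher numbers stand for an effect only at larger amounts of compound and lower numbers for an effect already at smaller amounts), compound 1 `NCCC(c1cccc(F)c1)c1cccc(F)c1` gives 2.1 mg/kg, compound 2 `CC(N)CC(c1cccc(F)c1)c1cccc(F)c1` gives 4.9 mg/kg and compound 3 `C[C@H](N)CC(c1cccc(F)c1)c1cccc(F)c1` gives 2.7 mg/kg. Compound 3 lies within the scatter of both others, while a 2.3-fold higher number from compound 1 to compound 2 (0.37 log units; beyond the scatter) lies just beyond it.

Compound 4 `C[C@@H](N)CC(c1cccc(F)c1)c1cccc(F)c1` alters one feature: the two compounds have the same atoms and bonds and differ only in configuration as drawn: 1 of 1 stereo elements differ; a stereocentre at a saturated chain carbon is drawn S in compound 3 and R in compound 4, a stereocentre at a saturated chain carbon drawn S in compound 3 and R in compound 4.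

The closest evidence is a 1.8-fold lower number from compound 2 to compound 3 (0.26 log units; within the scatter), which stays within the scatter; what separates that pair is the fact that one of compounds 2 and 3 is drawn with a defined configuration and the other without, at the place where they differ. The methyl step a 1.3-fold higher number from compound 1 to compound 3 (0.11 log units; within the scatter) also stays within the scatter, so it says little about the R form. If compound 2 holds both configurations, which the data do not establish, a 1.8-fold lower number from compound 2 to compound 3 (0.26 log units; within the scatter) is a weak hint that the R form contributes less. A higher number is therefore expected in this assay, with wide uncertainty. The expected step is a 3.0-fold higher number from compound 3 to compound 4 (0.47 log units; beyond the scatter). Compound 4 is estimated at 8 mg/kg, with an expected range of 3.5 mg/kg to 22 mg/kg.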

Compound 4, dose for half-maximal effect: 9.1 mg/kg
For compound 4 the middle estimate is 1.1-fold (0.06 log units) below the measured one; low and high end bracket the measured number.
By their numbers in this assay, from the lowest: compounds 1, 3, 2 and 4 (each within the scatter of the next, the first and the last beyond it).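

In this assay the configuration at the saturated chain carbon bearing the methyl is now seen to matter, with a 3.4-fold higher number from compound 3 to compound 4 (0.53 log units; beyond the scatter), and the pair differs in one respect only: the fact that compounds 3 and 4 differ only in the configuration as drawn

The methyl step therefore depends on configuration: the R form gives a 4.3-fold higher number from compound 1 to compound 4 (0.64 log units; beyond the scatter), while the S form stays within the scatter of the unmethylated compound 1 in a 1.3-fold higher number from compound 1 to compound 3 (0.11 log units; within the scatter).

Compound 2 cannot be separated from either defined form, since a 1.9-fold higher number from compound 2 to compound 4 (0.27 log units; within the scatter) and a 1.8-fold lower number from compound 2 to compound 3 (0.26 log units; within the scatter) both stay within the scatter, and the comparison carries this caveat: the fact that one of compounds 2 and 4 is drawn with a defined configuration and the other without, at the place where they differ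

On these data alone, whether an ethyl group at this carbon would show the same gap between the S and R forms remains open. So does whether that gap persists with a secondary amine, such as the N-methyl amine, in place of the primary amine.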